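Removing an Acetyl Group from Two Cytotoxic Scaffolds

The compounds below may be only part of what the source reports. "The series", "measured", "known", "first", "only" and "open" are said of these compounds alone.

Compound 1 `COc1ccc(C2=C(c3cc(OC)c(OC)c(OC)c3)C(=O)C(O)C2)cc1Cl`: 20 ug/mL
Compound 2 `COc1ccc(C2=C(c3cc(OC)c(OC)c(OC)c3)C(=O)C(OC(C)=O)C2)cc1Cl`: 3.5 ug/mL
Compound 3 `CC(=O)OC1C/C(=N/O)C(c2ccccc2)=C1c1ccccc1`: > 100 ug/mL

These compounds were tested in an ADME assay on ECV-304 cells (Homo sapiens) for cytotoxicity, read by MTT assay, with a stated time of 72 h; a higher number here means a weaker inhibitor, a lower number a stronger inhibitor. Compound 2 gives 3.5 ug/mL, while compound 1 gives 20 ug/mL. The two differ in one place, (hydrogen in place of acetyl on an oxygen on a saturated carbon), and this change made a step of a 5.7-fold higher number from compound 2 to compound 1 (0.76 log units; beyond the scatter). Compound 3 gives only a limit of the assay, > 100 ug/mL. Its value sits at the limit of > 100 ug/mL in this assay, at which 1 of the 3 values shown sits. The difference between the core of compound 3 and the core of compound 2 is not broken down here.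

Compound 4 `O/N=C1/CC(O)C(c2ccccc2)=C1c1ccccc1` has not yet been measured. It differs from compound 3 by hydrogen in place of acetyl on an oxygen on a saturated carbon, the same change as that seen between compound 2 and compound 1, at the same place. In this assay the step from compound 3 to compound 4 is expected to be a step that the limit leaves unreadable from compound 3 to compound 4, resting on the earlier step of a 5.7-fold higher number from compound 2 to compound 1 (0.76 log units; beyond the scatter) and on compound 3 already standing at the limit of > 100 ug/mL in this assay, at which 1 of the 3 values shown sits. Compound 4 is therefore expected at about 300 ug/mL, most likely reported again only as a limit, with a plausible range from 100 ug/mL to 1000 ug/mL.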

Compound 4, half-maximal inhibitory concentration: > 100 ug/mL
Compound 4: only a limit was reported; the forecaster's own chance of this, stated with the estimate: 85%; the middle value does not contradict the limit.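

In this assay, compound 3 and compound 4 are both reported only as a limit, not as a number, so no step between them can be read: the limit of > 100 ug/mL in this assay, at which 2 of the 4 values shown sit.

The compounds shown leave open whether hydrogen in place of acetyl changes the result at all on the core of compound 3, as it does on the core of compound 2.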